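Adding a Methoxycarbonyl to the Pyridine of Compound 1

The source may hold more compounds than are shown below. What is called first, only, known or untested is meant among the compounds shown, and "the series" means these compounds.

Going by the values given here, compound 1, `c1ccc(CCCCCCCc2nnc(-c3ccccn3)o2)cc1`, gives 60000 nM in an assay for inhibition of Fatty-acid amide hydrolase 1 (Rattus norvegicus) (a higher number here means a weaker inhibitor, a lower number a stronger inhibitor), the highest of the two numbers known so far. Its nearest neighbour is compound 2, `c1ccc(CCCCCCCc2nnc(-c3ccco3)o2)cc1`, which gives 18000 nM; the step of a 3.3-fold lower number from compound 1 to compound 2 (0.52 log units; beyond the scatter) is modest. Compound 3, `COC(=O)c1cccc(-c2nnc(CCCCCCCc3ccccc3)o2)n1`, differs from compound 1 by methoxycarbonyl in place of hydrogen on an aromatic carbon, placed next to the ring nitrogen and meta to a large group. Among the compounds with values here, no measured step touches this change, so the expectation rests on compound 1 alone. Compound 3 is expected to give 40000 nM, between 8000 nM and 200000 nM, a step of a 1.5-fold lower number from compound 1 to compound 3 (0.18 log units; within the scatter) that is an estimate only.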

Compound 3, inhibition constant: > 2500 nM
Compound 3: only a limit was reported (the forecaster's own chance of this, stated with the estimate: 25%); the middle value lies beyond the limit too.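

The step from compound 1 to compound 3 cannot be read, because compound 3 gave only a limit and not a number: the limit of > 2500 nM in this assay, at which 1 of the 3 values shown sits.

The compounds shown leave open how far methoxycarbonyl in place of hydrogen on an aromatic carbon shifts the number in this assay, or in which direction.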